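The source may report more compounds than this note shows. Statements on the series, on what has been measured and on what is new or still open speak of the compounds shown alone.

Measured so far in the series:
compound 1, `CSCn1c(=N)sc2cc(OC(F)(F)F)ccc21`: 3 mg/kg
compound 2, `CSCCn1c(=N)sc2cc(OC(F)(F)F)ccc21`: 1 mg/kg
compound 3, `CCCSCCn1c(=N)sc2cc(OC(F)(F)F)ccc21`: 2.4 mg/kg

In a functional assay on the whole organism with Rattus norvegicus as the target (on this read-out higher numbers stand for an effect only at larger amounts of compound and lower numbers for an effect already at smaller amounts), compound 3 holds the second highest of the three numbers. Its nearest neighbour is compound 1: the step of a 1.3-fold lower number from compound 1 to compound 3 (0.10 log units; within the scatter) stays within the scatter, whereas the step of a 2.4-fold higher number from compound 2 to compound 3 (0.38 log units; beyond the scatter) lies beyond it.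

Compound 4, `CN(C)CCCn1c(=N)sc2cc(OC(F)(F)F)ccc21`, differs from compound 3 by (dimethylamino)methyl in place of propylsulfanyl on a saturated chain carbon, two bonds along the chain from an aromatic nitrogen. For the measured compounds named here, no measured step covers an exchange of sulfur for nitrogen. The steps of a 3.0-fold lower number from compound 1 to compound 2 (0.48 log units; beyond the scatter) and a 2.4-fold higher number from compound 2 to compound 3 (0.38 log units; beyond the scatter) concern only the chain between the aromatic nitrogen and the sulfur and what sits on that sulfur, so they give no direction for this change. Compound 4 is therefore expected to land within the span of the three measured numbers, with the expected step of a 1.2-fold lower number from compound 3 to compound 4 (0.08 log units; within the scatter) small. Compound 4 is estimated at 2 mg/kg, range 0.6 mg/kg to 7 mg/kg.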

Compound 4, dose for half-maximal effect: 9 mg/kg
The estimate for compound 4 lay 4.5-fold (0.65 log units) below the measured number; measured number above the stated range.
By their numbers in this assay, from the lowest: compound 2; then compounds 3 and 1 (each within the scatter of the next); then compound 4.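

In this assay, (dimethylamino)methyl in place of propylsulfanyl gives a 3.8-fold higher number from compound 3 to compound 4 (0.57 log units; beyond the scatter), so this position responds to the exchange even though the heavy-atom and acceptor counts stay the same. The other two comparisons point the same way, with a 9.0-fold higher number from compound 2 to compound 4 (0.95 log units; beyond the scatter) and a 3.0-fold higher number from compound 1 to compound 4 (0.48 log units; beyond the scatter), which puts compound 4 beyond the scatter of all three sulfur compounds, with the highest number. Nothing available gives a cause for these steps.

Open, on these data alone, is whether the step follows the nitrogen itself or its two methyl groups. A primary amine or an ether oxygen at the same place on the chain would separate the two.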